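The source may hold more compounds than are shown below. What is called first, only, known or untested is meant among the compounds shown, and "the series" means these compounds.

Working notes on the series. The shared core is kept throughout and the group on a triple-bonded carbon is varied. Compound 1 `CCCCCc1ccc(C#Cc2nc(C(N)=O)nn2COCCO)cc1` carries pentyl on an aromatic carbon; in an ADME assay on Huh-5-2 cells (Homo sapiens) for cytotoxicity (on this read-out lower numbers stand for higher toxicity in this test and higher numbers for lower toxicity in this test), compound 1 gives 25 ug/mL. Compound 2 `NC(=O)c1nc(C#Cc2ccc(C(F)(F)F)cc2)n(COCCO)n1` carries trifluoromethyl there, and in this assay compound 2 gives 20 ug/mL; the step is a 1.3-fold lower number from compound 1 to compound 2 (0.10 log units; within the scatter). Compound 3 `NC(=O)c1nc(C#Cc2ccc(F)cc2)n(COCCO)n1` carries fluoro. In this assay compound 3 reaches only the limit of the test, > 50 ug/mL, so a limit and not a number is known for it; this is the limit of > 50 ug/mL in this assay, at which 1 of the 3 values shown sits. The steps towards it are an at least 2.0-fold higher number from compound 1 to compound 3 (0.30 log units; that floor lies within the scatter) and an at least 2.5-fold higher number from compound 2 to compound 3 (0.39 log units; beyond the scatter), the second beyond the scatter. Compound 3 therefore stands at the limit of the test rather than on a measured figure.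

Compound 4 `NC(=O)c1nc(C#CC2(O)CCCCC2)n(COCCO)n1` is not yet measured. The change is 1-hydroxycyclohexyl in place of 4-fluorophenyl on a triple-bonded carbon. Among the measured compounds shown here, none of the measured steps exchanges the aromatic ring itself; the two steps ending at compound 3 alter only the substituent on that ring, so they give no direct guide to this exchange. With compound 3 already at the limit, the expectation for compound 4 in this assay is a step of about a number no higher from compound 3 to compound 4 (the limit leaves the size open), that is, none beyond the scatter. The estimate for compound 4 is 50 ug/mL, with a range of 25 ug/mL to 100 ug/mL, and the test may again report only a limit.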

Compound 4, half-maximal cytotoxic concentration: > 50 ug/mL
Compound 4: a limit, no number; the forecaster's own chance of this, stated with the estimate: 55%; the middle value sits exactly at the limit.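

In this assay compound 3 and compound 4 both rest on a limit and not on a number, so no step between them can be read: the limit of > 50 ug/mL in this assay, at which 2 of the 4 values shown sit.

The compounds shown leave open whether 1-hydroxycyclohexyl in place of 4-fluorophenyl on a triple-bonded carbon changes the read-out at all, and how far past the limit either compound lies.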